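A Methyl on the Ring Nitrogen: Compound 2 to Compound 3

This account rests on a few compounds, and the source may have more. Where it says the series, first, only, none or still open, it means among the compounds named here.

Of the compounds shown here, two built on one shared core have been measured. Compound 1 `Nc1n[nH]c2cc(-c3cccnc3)[nH]c(=O)c12` and compound 2 `Nc1n[nH]c2cc(-c3ccccn3)[nH]c(=O)c12` differ only in their aromatic substituent. In an assay on isolated protein for inhibition of serine/threonine-protein kinase D2 (Homo sapiens), read by mobility shift assay, tested at 30 uM (on this read-out higher numbers stand for more inhibition at the one concentration tested (going by the name of the read-out) and lower numbers for less inhibition), compound 1 gives 26%, and in the same assay compound 2 gives 33%. Compound 2 carries the larger of the two numbers, but the gap between them lies within the usual scatter, so neither compound stands apart from the other.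

Compound 3 `Cn1nc(N)c2c(=O)[nH]c(-c3ccccn3)cc21` is not yet measured. It differs from compound 2 by methyl in place of hydrogen on an aromatic nitrogen. Going by the values given here, both measured compounds keep a hydrogen at that ring nitrogen, so no measured step shows what its replacement does. The account expects a step downward beyond the scatter, a number 18 percentage points lower from compound 2 to compound 3 (beyond the scatter). For compound 3 the estimate in this assay is 15%, with a range from 0% to 40%.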

Compound 3, a percentage reported as inhibition, at one concentration (the size of the read-out at that concentration, not a potency): 17%
Estimate against measurement, compound 3: 2 percentage points below; the range from low to high includes it.
By their numbers in this assay, from the lowest: compounds 3, 1 and 2 (each within the scatter of the next, the first and the last beyond it).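

In this assay the change of hydrogen to methyl on this aromatic nitrogen gives a number 16 percentage points lower from compound 2 to compound 3 (beyond the scatter) and so supplies the only step shown at this position, one that the two earlier compounds, both of which keep the hydrogen, could not reveal. The loss is only partial, since compound 3 still gives 17% at the one concentration tested, with the rest of compound 2 unchanged. Nothing available explains why the number falls at this position.

The compounds shown leave open whether the drop follows from losing the hydrogen or from the methyl itself, and an ethyl group, a longer chain or a hydroxyethyl group on the same nitrogen would bear on that. They also leave open whether the same change carries over to the aromatic substituent of compound 1.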